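A Methyl Added to Cores That Show No Measurable Inhibition

The source may hold more compounds than are shown below. What is called first, only, known or untested is meant among the compounds shown, and "the series" means these compounds.

Compound 3 `Cc1ncn2c(S)nncc12` and compound 1 `Cc1nc(C)n2c(S)nncc12` share one core. In a functional assay for inhibition, with Homo sapiens as the target (a higher number here means a weaker inhibitor, a lower number a stronger inhibitor), compound 3 gives > 48000 nM, a limit of the assay rather than a number. In this assay compound 1 gives > 48000 nM, again a limit. The change between them is methyl in place of hydrogen on an aromatic carbon, and because both values sit at the limit of > 48000 nM in this assay, at which 3 of the 3 values shown sit, the step that the two limits leave unreadable from compound 3 to compound 1 cannot be read. Compound 2 `CCCc1nc(C)c2cnnc(SC)n12` rests on a different core; the difference between the two cores is not broken down here. In this assay compound 2 gives > 48000 nM, also a limit. Compound 4 `CCCc1nc(C)c2c(C)nnc(SC)n12` differs from compound 2 by methyl in place of hydrogen on an aromatic carbon. This is the same kind of change as that from compound 3 to compound 1, not the same: in compound 1 the methyl enters on a five-membered aromatic ring with 2 nitrogen, between two ring nitrogen atoms, whereas in compound 4 it enters on a six-membered aromatic ring with 3 nitrogen, para to a methylsulfanyl group. Because all three measured values sit at the limit of > 48000 nM in this assay, at which 3 of the 3 values shown sit, the step is expected to be about a step that the limit leaves unreadable from compound 2 to compound 4. Compound 4 is accordingly estimated at 70000 nM, most probably again reported only as a limit.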

Compound 4, half-maximal inhibitory concentration: > 48000 nM
Compound 4: a limit, no number; the forecaster's own chance of this, stated with the estimate: 80%; the middle value is on the limit's open side.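

No step can be read from compound 2 to compound 4, because neither compound gives a number and both rest on the same assay limit: the limit of > 48000 nM in this assay, at which 4 of the 4 values shown sit. The compounds shown leave open whether either added methyl changes inhibition at all, and which structures would give a measurable value.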